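This account rests on a few compounds, and the source may have more. Where it says the series, first, only, none or still open, it means among the compounds named here.

Measured compounds:
Compound 2, `CCC1(CCCCN2CCN(c3ccc(Cl)cc3)CC2)C(=O)Nc2ccccc21`: 10 mg/kg
Compound 1, `CCC1(CCCCN2CCN(c3ccc(OC)cc3)CC2)C(=O)Nc2ccccc21`: > 20 mg/kg, a limit of the assay
Compound 3, `CCC1(CCCCN2CCN(c3ccccc3Cl)CC2)C(=O)Nc2ccccc21`: > 20 mg/kg, a limit of the assay

All three were tested in a functional assay on the whole organism (strain Wistar) with Rattus norvegicus as the target, with a stated time of 5 min; a lower number here means that less compound is needed, a higher number that more compound is needed for the effect. The change from compound 2 to compound 1 is methoxy in place of chloro on an aromatic carbon, and it gave an at least 2.0-fold higher number from compound 2 to compound 1 (0.30 log units; that floor lies within the scatter). The cores of compound 2 and compound 3 differ by 2-chlorophenyl in place of 4-chlorophenyl on an amine nitrogen in a ring, a step of an at least 2.0-fold higher number from compound 2 to compound 3 (0.30 log units; that floor lies within the scatter). Between compound 1 and compound 3 the step is a step that the two limits leave unreadable from compound 1 to compound 3. Compound 4, `CCC1(CCCCN2CCN(c3ccccc3OC)CC2)C(=O)Nc2ccccc21`, is not yet measured; it differs from compound 3 by methoxy in place of chloro on an aromatic carbon, the same kind of change as from compound 2 to compound 1, though there the group sat para to a large group and here ortho to a large group. Because compound 3 already sits at the limit of > 20 mg/kg in this assay, at which 2 of the 3 values shown sit, and the earlier change gave an at least 2.0-fold higher number from compound 2 to compound 1 (0.30 log units; that floor lies within the scatter), compound 4 is expected at 40 mg/kg, from 15 mg/kg to 120 mg/kg. The estimated step is a step that the limit leaves unreadable from compound 3 to compound 4.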

Compound 4, minimum effective dose: 10 mg/kg
Compound 4: middle estimate off by 4.0-fold (0.60 log units), on the high side; measured number outside the range, below it.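

In this assay, methoxy in place of chloro on an aromatic carbon did not carry over from one core to the other: the same change on two cores in this assay, an at least 2.0-fold higher number (0.30 log units; that floor lies within the scatter) from compound 2 to compound 1 and an at least 2.0-fold lower number (0.30 log units; that floor lies within the scatter) from compound 3 to compound 4, at least 4.0-fold (0.60 log units) apart, beyond the scatter of two such steps

With the group ortho to a large group, the change gave an at least 2.0-fold lower number from compound 3 to compound 4 (0.30 log units; that floor lies within the scatter); the other two new comparisons gave an at least 2.0-fold lower number from compound 1 to compound 4 (0.30 log units; that floor lies within the scatter) and no change at the digits printed from compound 2 to compound 4 (within the scatter). Compound 1 and compound 3 each stand at a limit of the assay, so the true sizes of their steps stay unknown, and these two pairs give neither a rule for other cores nor a reason for the gap.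

Still open, on these data alone, is whether fluoro or ethoxy on the aromatic ring would follow compound 3 or compound 4. Also open, as far as these compounds go, is whether a longer chain on the shared core would preserve this difference.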